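Chloro for Methyl on the Aromatic Ring of Compound 1

The source may report more compounds than this note shows. Statements on the series, on what has been measured and on what is new or still open speak of the compounds shown alone.

Within the data shown here, compound 1 `Cc1cccc2c1CC/C2=C\C(=O)NC1CC1` is the only compound with a number in a functional assay on the whole organism with Mus musculus as the target; on this read-out lower numbers stand for an effect already at smaller amounts and higher numbers for an effect only at larger amounts of compound; there compound 1 gives 40 mg/kg. Compound 2 `Cc1cccc2c1CC/C2=C\C(N)=O` in this assay reaches only a limit of > 100 mg/kg. Among the measured compounds shown here, the single measured step, an at least 2.5-fold higher number from compound 1 to compound 2 (0.39 log units; beyond the scatter), concerns the amide-type nitrogen and not the ring. Compound 3 `O=C(/C=C1\CCc2c(Cl)cccc21)NC1CC1` differs from compound 1 by chloro in place of methyl on an aromatic carbon. For the measured compounds named here, no measured step touches an aromatic carbon, so nothing here argues for a shift beyond the scatter in this assay. For compound 3 a step within the scatter is expected, no change at the digits printed from compound 1 to compound 3 (within the scatter). Compound 3 is therefore estimated at 40 mg/kg, between 18 mg/kg and 90 mg/kg.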

Compound 3, dose for half-maximal effect: 58 mg/kg
Compound 3: middle estimate off by 1.5-fold (0.16 log units), on the low side; measured number inside the range.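

In this assay, among these compounds, chloro in place of methyl on this aromatic carbon gives the only step read at the ring: a 1.5-fold higher number from compound 1 to compound 3 (0.16 log units; within the scatter). Among the compounds shown here, the position therefore tolerates this exchange without a shift beyond the scatter, whereas the one earlier step concerned the amide-type nitrogen. No measurement shown gives a reason for this result. The compounds shown leave open how an amine, a carboxylic acid or a longer chain would read on this aromatic carbon. They also leave open whether chloro or methyl on the other aromatic carbons would read the same.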